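From carboxy to ethoxycarbonyl in the series

This account rests on a few compounds, and the source may have more. Where it says the series, first, only, none or still open, it means among the compounds named here.

In a functional assay on Rec1 cells (Homo sapiens) for inhibition, read by luminescence and CellTiter-Glo, with a stated time of 72 h (a higher number here means a weaker inhibitor, a lower number a stronger inhibitor), compound 1 (`C/C=C/C(=O)Nc1cccc(Cn2nc(-c3ccc(Oc4ccccc4)cc3)cc2C(=O)OCC)c1`) gives 7800 nM. Compound 2 (`O=C(CCl)Nc1ccc(Cn2nc(-c3ccc(Oc4ccccc4)cc3)cc2C(=O)O)cc1`) gives 4000 nM, which lies within the scatter of the value for compound 1, so the two cannot be ranked. Compound 3 (`CCOC(=O)c1cc(-c2ccc(Oc3ccccc3)cc2)nn1Cc1ccc(NC(=O)CCl)cc1`) departs from compound 2 by a single change: ethyl in place of hydrogen on an oxygen next to a carbonyl group. This is ethyl in place of hydrogen on an oxygen next to a carbonyl group, or carboxy to ethoxycarbonyl. Among the measured compounds shown here, no step between measured compounds isolates this change. Compound 1 also carries ethoxycarbonyl, but it differs from compound 2 elsewhere too, so it offers no clean comparison. A modest step towards a lower number in this assay is expected, possibly no larger than the scatter. The expected change is a 1.6-fold lower number from compound 2 to compound 3 (0.20 log units; within the scatter). For compound 3 the estimate is 2500 nM, with an expected range of 800 nM to 8000 nM.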

Compound 3, half-maximal inhibitory concentration: 400 nM
Beside the measured number, compound 3's estimate is 6.3-fold (0.80 log units) above it; the measured number lies below the stated range.
By their numbers in this assay, from the lowest: compound 3; then compounds 2 and 1 (each within the scatter of the next).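

In this assay, among the compounds shown here, ethyl in place of hydrogen on an oxygen next to a carbonyl group gives a 10-fold lower number from compound 2 to compound 3 (1.00 log units; beyond the scatter) with nothing else altered, the first clean reading of carboxy to ethoxycarbonyl. With ethoxycarbonyl kept, 4-(((chloromethyl)carbonyl)amino)phenyl in place of 3-(((prop-1-en-1-yl)carbonyl)amino)phenyl on a saturated chain carbon bound to an aromatic nitrogen gives a 20-fold lower number from compound 1 to compound 3 (1.29 log units; beyond the scatter) and so shows that this second place also matters, which the unrankable values of compound 1 and compound 2 could not show. Nothing available explains either step.

Whether the gain is specific to ethoxycarbonyl stays open, since a methyl ester, a longer alkyl ester or a primary amide at this place is not among the compounds shown. The second step also joins a change of acyl group with a change of ring position, so the share of each remains unresolved.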